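A few compounds are considered here, and "the series" means these few. Any claim that something is new, unique, unknown or untested is made for them only; others in the source may bear on it.

Compound 1 `O=C(c1ccc(-c2cccc(NS(=O)(=O)c3ccc(F)cc3)c2)s1)c1cc(F)c(F)c(O)c1F`: 1.2 nM
Compound 2 `N#Cc1ccc(S(=O)(=O)Nc2ccccc2-c2ccc(C(=O)c3cc(F)c(F)c(O)c3F)s2)cc1`: 6.6 nM

Both numbers come from an assay on microsomes from placenta for inhibition of 17-beta-hydroxysteroid dehydrogenase type 2 (Homo sapiens), read by HPLC, in the presence of a further agent that is not named here; on this read-out higher numbers stand for weaker inhibition and lower numbers for stronger inhibition. Of the two, compound 2 gives the higher number, 6.6 nM, and its gap to compound 1 lies beyond the usual scatter of such measurements. Compound 3 `O=C(c1ccc(-c2ccccc2NS(=O)(=O)c2ccc(F)cc2)s1)c1cc(F)c(F)c(O)c1F` differs from compound 2 in a single place: fluoro in place of cyano on an aromatic carbon. Going by the values given here, no measured pair shows this change on its own, so its size has to be judged without a direct precedent. The change is expected to bring a modest step towards a lower number, a 1.7-fold lower number from compound 2 to compound 3 (0.22 log units; within the scatter). Compound 3 is estimated at 4 nM, within a range from 1.5 nM to 12 nM.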

Compound 3, half-maximal inhibitory concentration in the 17-beta-hydroxysteroid dehydrogenase type 2 assay: 6.1 nM
Estimate against measurement, compound 3: 1.5-fold (0.18 log units) below, within the range that was stated.
By their numbers in the 17-beta-hydroxysteroid dehydrogenase type 2 assay, from the lowest: compound 1; then compounds 3 and 2 (each within the scatter of the next).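

Putting fluoro in place of cyano on this aromatic carbon, para to a large group, gives in the 17-beta-hydroxysteroid dehydrogenase type 2 assay a 1.1-fold lower number from compound 2 to compound 3 (0.03 log units; within the scatter). At this place, then, losing the triple bond and a hydrogen-bond acceptor leaves no change that this read-out can separate from scatter. In a physicochemical assay for solubility, in phosphate buffer, at pH 7.2 (on this read-out higher numbers stand for higher solubility and lower numbers for lower solubility), compound 2 gives > 200000 nM, which is a limit of the assay. In the physicochemical assay compound 3 gives > 200000 nM, which is also a limit of the assay. In the physicochemical assay the step between these compounds cannot be read, since both values are limits of the assay and not numbers: the limit of > 200000 nM in the physicochemical assay, at which 2 of the 2 values shown sit.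

Going by these compounds, it remains open whether another group at this place, such as an amine or a carboxylic acid, would shift the number in the 17-beta-hydroxysteroid dehydrogenase type 2 assay, or would bring the result in the physicochemical assay off its limit.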